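Acylsulfonamide in place of urea on the shared core

A few compounds are considered here, and "the series" means these few. Any claim that something is new, unique, unknown or untested is made for them only; others in the source may bear on it.

Compound 3, `O=C(COc1ccc(Oc2ccccc2)cc1)Cn1ncc2cc(NC(=O)NC3CCCCC3)ccc21`, gives 840 nM in an assay on microsomes from brain for inhibition of Fatty-acid amide hydrolase 1 (Rattus norvegicus), read by fluorescence and HPLC, with a stated time of 45 min (on this read-out higher numbers stand for weaker inhibition and lower numbers for stronger inhibition), the lowest number among the three measured compounds, and its steps to both of the others lie beyond the scatter. Compound 1, `O=C(COc1ccc(Oc2ccccc2)cc1)Cn1ncc2ccccc21`, gives 2600 nM; compound 2, `COC(=O)Nc1ccc2c(cnn2CC(=O)COc2ccc(Oc3ccccc3)cc2)c1`, gives 4000 nM. The step from compound 1 to compound 2 was a 1.5-fold higher number from compound 1 to compound 2 (0.19 log units; within the scatter), whereas a 3.1-fold lower number from compound 1 to compound 3 (0.49 log units; beyond the scatter) and a 4.8-fold lower number from compound 2 to compound 3 (0.68 log units; beyond the scatter) were both modest but beyond the scatter.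

Compound 4, `O=C(COc1ccc(Oc2ccccc2)cc1)Cn1ncc2cc(C(=O)NS(=O)(=O)C(F)(F)F)ccc21`, differs from compound 3 in one place: ((trifluoromethyl)sulfonyl)carbamoyl in place of (cyclohexylcarbamoyl)amino on an aromatic carbon. Within the data shown here, the steps that bear on this position show that what stands there can move the number in either direction. None of them tests the entering group; the nearest comparison is the reversal of the step from compound 1 to compound 3, which would return the number toward that of compound 1. For compound 4 a modest rise in this assay is therefore expected, about a 3.0-fold higher number from compound 3 to compound 4 (0.47 log units; beyond the scatter), with the direction uncertain given the unrelated nature of the new group. Compound 4 is estimated at 2500 nM, within a range of 700 nM to 9000 nM.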

Compound 4, half-maximal inhibitory concentration: 510 nM
For compound 4 the middle estimate is 4.9-fold (0.69 log units) above the measured one; measured number below the stated range.
By their numbers in this assay, from the lowest: compounds 4 and 3 (each within the scatter of the next); then compounds 1 and 2 (each within the scatter of the next).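

The ((trifluoromethyl)sulfonyl)carbamoyl group and the (cyclohexylcarbamoyl)amino group are not separated at this aromatic carbon in this assay, with a 1.6-fold lower number from compound 3 to compound 4 (0.22 log units; within the scatter) as the step between them, so a group with no ring, joined through its carbonyl carbon, serves here as well as a urea carrying a six-membered non-aromatic ring of carbon only. The new group also stands clear of both simpler members of the series, with a 5.1-fold lower number from compound 1 to compound 4 (0.71 log units; beyond the scatter) against hydrogen and a 7.8-fold lower number from compound 2 to compound 4 (0.89 log units; beyond the scatter) against (methoxycarbonyl)amino, which gives a second, chemically unrelated substituent that lowers the number relative to compound 1. No measurement shown here offers an explanation for this result.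

Open, from the compounds shown here alone, is which part of the entering group carries the step from compound 1: a carboxylic acid or a plain carboxamide on the same aromatic carbon would test the carbonyl part alone, and a methylsulfonylcarbamoyl group would test the three fluorines. Also open, going by these compounds, is whether a cyclohexyl or phenyl group on the sulfonyl end would take the number beyond the scatter of compound 3 and compound 4.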